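The compounds below may be only part of what the source reports. "The series", "measured", "known", "first", "only" and "open" are said of these compounds alone.

Series read in a functional assay on MDA-MB-231 cells (Homo sapiens) for antiproliferative activity, read by sulforhodamine B assay, with a stated time of 48 h; on this read-out lower numbers stand for stronger inhibition and higher numbers for weaker inhibition; measured compounds:
compound 1 `COc1ccc2nc(-c3ccc(N/C=C\C(=O)c4ccc(OC)c([N+](=O)[O-])c4)c(C)c3)sc2c1` gives 17600 nM
compound 2 `COc1ccc(C(=O)/C=C\Nc2ccc(-c3nc4cc(OC)c(OC)c(OC)c4s3)cc2)cc1F` gives 16500 nM
compound 3 `COc1ccc2nc(-c3ccc(N/C=C\C(=O)c4cc(OC)c(OC)c([N+](=O)[O-])c4)c(C)c3)sc2c1` gives 5050 nM

The change from compound 3 to compound 1 is hydrogen in place of methoxy on an aromatic carbon; it gave a 3.5-fold higher number from compound 3 to compound 1 (0.54 log units; beyond the scatter). The difference between the cores of compound 2 and compound 3 is not broken down here. Compound 4 `COc1cc(OC)c2sc(-c3ccc(N/C=C\C(=O)c4ccc(OC)c(F)c4)cc3)nc2c1` is still to be measured; it differs from compound 2 by hydrogen in place of methoxy on an aromatic carbon. The surroundings of the two places differ: in compound 3 the methoxy is ortho to a methoxy group, meta to a large group and meta to a nitro group, whereas in compound 2 it is on a ring that is part of a fused or bridged system of two rings, ortho to two methoxy groups, meta to a fused ring and para to a fused ring, so this is the same kind of change, not the same. From compound 2 to compound 4 a step of about a 1.5-fold higher number from compound 2 to compound 4 (0.18 log units; within the scatter) is expected in this assay, smaller than the earlier one and resting on the earlier step of a 3.5-fold higher number from compound 3 to compound 1 (0.54 log units; beyond the scatter) together with the differing surroundings. Compound 4 is thus estimated at 25000 nM, between 10000 nM and 60000 nM.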

Compound 4, half-maximal inhibitory concentration: 6700 nM
Compound 4: the middle estimate sits 3.7-fold (0.57 log units) above what was measured; measured number outside the range, below it.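

In this assay, hydrogen in place of methoxy on an aromatic carbon gave a 2.5-fold lower number from compound 2 to compound 4 (0.39 log units; beyond the scatter). Going by these compounds alone, the earlier step on the other core ran the opposite way, so neither the direction nor the size of this change carries over from one core to the other: the same change on two cores in this assay, a 3.5-fold higher number (0.54 log units; beyond the scatter) from compound 3 to compound 1 and a 2.5-fold lower number (0.39 log units; beyond the scatter) from compound 2 to compound 4, 8.6-fold (0.93 log units) apart, beyond the scatter of two such steps With only one pair on each core, this does not show whether the core itself or the surroundings of the methoxy set the direction, nor how a further core would respond.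

Still open, from the compounds shown here alone, is whether a hydroxy group or an amine at the same place would follow the hydrogen on each core. Also open, going by these compounds, is whether the split between the two cores would hold for such groups.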